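The source may hold more compounds than are shown below. What is called first, only, known or untested is meant among the compounds shown, and "the series" means these compounds.

Working notes on the naphthyl amide series.

The shared core is the hexafluoro-hydroxypropyl naphthylamide, varied only at the carbonyl carbon of the amide. In an assay on LtK cells with ATP-sensitive inward rectifier potassium channel 11 (Homo sapiens) as the target (a higher number here means that more compound is needed for the effect, a lower number that less compound is needed), compound 1 `O=C(Nc1c(C(O)(C(F)(F)F)C(F)(F)F)ccc2ccccc12)C1CCC1` gives 45 nM. Compound 3 `O=C(Nc1c(C(O)(C(F)(F)F)C(F)(F)F)ccc2ccccc12)c1ccc(Cl)c(Cl)c1` gives 194 nM in this assay. Compound 2 `Cc1ccccc1C(=O)Nc1c(C(O)(C(F)(F)F)C(F)(F)F)ccc2ccccc12` gives 5550 nM in this assay, the highest of the three numbers: the step of a 120-fold higher number from compound 1 to compound 2 (2.09 log units; beyond the scatter) is large, and so is the step of a 29-fold lower number from compound 2 to compound 3 (1.46 log units; beyond the scatter), so compound 2 sits well apart from both others.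

The next compound, compound 4 `O=C(Nc1c(C(O)(C(F)(F)F)C(F)(F)F)ccc2ccccc12)c1cnco1`, is not yet measured. It differs from compound 2 in one place: 1,3-oxazol-5-yl in place of 2-methylphenyl on a carbonyl carbon.

Among the compounds with values here, the steps that bear on this change are those that leave the 2-methylphenyl group, above all a 29-fold lower number from compound 2 to compound 3 (1.46 log units; beyond the scatter), where an aromatic ring of a different kind on the same carbonyl carbon gave a much lower number, and a 120-fold higher number from compound 1 to compound 2 (2.09 log units; beyond the scatter) read backwards. Both say that moving away from 2-methylphenyl at this position gives a lower number in this assay. Within the data shown here, no measured compound carries a five-membered ring at the carbonyl carbon, so the size of the move is uncertain. For compound 4 the expected step is a 14-fold lower number from compound 2 to compound 4 (1.14 log units; beyond the scatter), a lower number, because of the direction of a 29-fold lower number from compound 2 to compound 3 (1.46 log units; beyond the scatter). The estimate for compound 4 in this assay is 400 nM, with a range from 60 nM to 3000 nM.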

Compound 4, half-maximal effective concentration: 24 nM
Estimate against measurement, compound 4: 17-fold (1.22 log units) above; measured number outside the range, below it.
By their numbers in this assay, from the lowest: compounds 4 and 1 (each within the scatter of the next); then compound 3; then compound 2.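

An aromatic ring on this carbonyl carbon is not tied to a high number in this assay: 1,3-oxazol-5-yl in place of 2-methylphenyl gives a 230-fold lower number from compound 2 to compound 4 (2.36 log units; beyond the scatter) and in place of 3,4-dichlorophenyl gives an 8.1-fold lower number from compound 3 to compound 4 (0.91 log units; beyond the scatter) at the same position. Set against cyclobutyl, 1,3-oxazol-5-yl gives a 1.9-fold lower number from compound 1 to compound 4 (0.27 log units; within the scatter) so the two groups stand level, and the lowest numbers in the series now include both a non-aromatic and an aromatic group. What counts at this position is therefore the kind of aromatic ring, with the five-membered ring carrying 2 hetero atoms standing well apart from the two substituted phenyl rings in compound 2 and compound 3.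

The change from 2-methylphenyl to 1,3-oxazol-5-yl alters ring size, hetero atoms and hydrogen-bond acceptor count all at once, so these series data cannot separate them; an unsubstituted phenyl, a pyridine ring, a furan ring or a thiophene ring on the same carbonyl carbon would each bear on that question. Nothing measured here accounts for any of these steps.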